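This account rests on a few compounds, and the source may have more. Where it says the series, first, only, none or still open, it means among the compounds named here.

Measured so far, in a functional assay on 1321-N1 cells for agonist activity at Free fatty acid receptor 1 (Homo sapiens), read by calcium flux; a higher number here means that more compound is needed for the effect, a lower number that less compound is needed:
Compound 1, `O=C(O)CCc1ccc(NCc2ccccc2)cc1`, gives 759 nM.
Compound 2, `O=C(O)CCc1ccc(NCc2ccc(Oc3ccccc3)cc2)cc1`, gives 182 nM.

Going by the values given here, compound 2 stands at the lower of the two numbers; the only measured step, a 4.2-fold lower number from compound 1 to compound 2 (0.62 log units; beyond the scatter), is what separates them, so a group placed at that position has already once brought the number down.

Compound 3, `O=C(O)CCc1ccc(NCc2ccc(-c3ccccc3)cc2)cc1`, has not been measured. It differs from compound 2 in one place: phenyl in place of phenoxy on an aromatic carbon. Among the compounds with values here, no measured step covers this particular swap; the one step that bears on it is a 4.2-fold lower number from compound 1 to compound 2 (0.62 log units; beyond the scatter), which shows that a ring at this position is tolerated and helpful. Since compound 3 keeps such a ring, the expectation is a number close to that of compound 2, with a 1.4-fold higher number from compound 2 to compound 3 (0.14 log units; within the scatter) as the estimated step. For compound 3 the expected value in this assay is 250 nM, within a range from 100 nM to 650 nM.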

Compound 3, half-maximal effective concentration: 417 nM
Beside the measured number, compound 3's estimate is 1.7-fold (0.22 log units) below it, within the range that was stated.
By their numbers in this assay, from the lowest: compound 2; then compounds 3 and 1 (each within the scatter of the next).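

In this assay, swapping phenoxy for phenyl gives a 2.3-fold higher number from compound 2 to compound 3 (0.36 log units; beyond the scatter), so the two groups are not interchangeable here, and simply carrying an aromatic ring at this position is not enough to keep the number of compound 2. Set against the unsubstituted parent, phenyl gives a 1.8-fold lower number from compound 1 to compound 3 (0.26 log units; within the scatter), a step that cannot be told apart from repeat-measurement noise, so only phenoxy has a step beyond the scatter from the hydrogen of compound 1. No supporting data are available to explain the gap between phenoxy and phenyl.

The compounds shown leave open whether the oxygen of phenoxy itself matters, or whether a sulfur atom or a methylene group linking the two rings would hold the lower number. From the compounds shown here alone, how a longer chain, such as benzyloxy, would fare at this position also remains open.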